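The source may report more compounds than this note shows. Statements on the series, on what has been measured and on what is new or still open speak of the compounds shown alone.

Series notes, growth inhibition in a functional assay on SNB-19 cells (Homo sapiens) for inhibition, read by sulforhodamine B assay, with a stated time of 48 h; a lower number here means a stronger inhibitor of growth, a higher number a weaker inhibitor of growth:

- compound 1, `COc1ccc(-c2[nH]c3ccccc3c2/C=C(\C#N)S(=O)(=O)c2ccccc2)cc1`: 863 nM
- compound 2, `CC(=O)/C(=C\c1c(-c2ccccc2)[nH]c2ccccc12)S(=O)(=O)c1ccccc1`: 6100 nM
- compound 3, `N#C/C(=C\c1c(-c2ccccc2)[nH]c2ccccc12)S(=O)(=O)c1ccccc1`: 8300 nM

Compound 3 gives the highest of the three numbers in this assay. Its nearest neighbour is compound 2, a 1.4-fold higher number from compound 2 to compound 3 (0.13 log units; within the scatter), a gap that stays within the scatter, so no order between compound 2 and compound 3 is claimed. The furthest is compound 1, a 9.6-fold higher number from compound 1 to compound 3 (0.98 log units; beyond the scatter), which is beyond the scatter.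

Compound 4, `N#C/C(=C\c1c(-c2ccccc2)[nH]c2ccccc12)C(=O)c1ccccc1`, differs from compound 3 by benzoyl in place of phenylsulfonyl on a double-bonded chain carbon bound to a double-bonded chain carbon and a triple-bonded carbon. For the measured compounds named here, no measured step changes this group; the step from compound 2 to compound 3 swaps the other substituent on the chain and stayed within the scatter, and the step from compound 1 to compound 3 concerns the methoxy only. With nothing that bears directly on the exchange of phenylsulfonyl for benzoyl, the expectation is no step beyond the scatter, a 1.0-fold lower number from compound 3 to compound 4 (0.02 log units; within the scatter), with wide uncertainty. Compound 4 is therefore estimated at 8000 nM in this assay, within 2500 nM to 30000 nM.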

Compound 4, concentration for 50% growth inhibition: 16800 nM
Estimate against measurement, compound 4: 2.1-fold (0.32 log units) below; the range from low to high includes it.
By their numbers in this assay, from the lowest: compound 1; then compounds 2 and 3 (each within the scatter of the next); then compound 4.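

In this assay, the exchange of phenylsulfonyl for benzoyl gives a 2.0-fold higher number from compound 3 to compound 4 (0.31 log units; beyond the scatter), so the group at this place on the chain has a modest but readable effect on the number. The earlier change of the other substituent on the chain, a 1.4-fold higher number from compound 2 to compound 3 (0.13 log units; within the scatter), stayed within the scatter and gave no such reading. Nothing available accounts for the higher number with benzoyl in place of phenylsulfonyl.

The compounds shown leave open whether the same exchange gives a step of similar size when methoxy is present, as in compound 1. They also leave open how other groups at this place, such as methylsulfonyl, an amide or a carboxylic acid, would compare with phenylsulfonyl and benzoyl.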